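The source may report more compounds than this note shows. Statements on the series, on what has been measured and on what is new or still open speak of the compounds shown alone.

Two amides built on the same core have been measured. Compound 1 `O=C(NCN1CCC(c2cccc[n+]2[O-])CC1)c1ccc(F)c(Cl)c1` gives 63 nM in a functional assay on HEK293 cells for agonist activity at D(4) dopamine receptor (Homo sapiens), read by FLIPR; a lower number here means that less compound is needed, a higher number that more compound is needed for the effect. Compound 2 `Cc1cccc(C(=O)NCN2CCC(c3cccc[n+]3[O-])CC2)c1` gives 89 nM in this assay. Going by the values given here, the only step between them, a 1.4-fold higher number from compound 1 to compound 2 (0.15 log units; within the scatter), replaces one substituted ring with another, and its size lies within the scatter, so the two numbers cannot be told apart; compound 2 simply sits beside compound 1.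

Compound 3 `Cc1cc(C)cc(C(=O)NCN2CCC(c3cccc[n+]3[O-])CC2)c1` is not yet measured. It differs from compound 2 by methyl in place of hydrogen on an aromatic carbon: a methyl group enters on an aromatic carbon of the six-membered carbon-only ring, meta to a large group and meta to a methyl group, so that the ring reads 3,5-dimethylphenyl instead of 3-methylphenyl.

Among the compounds with values here, only the step from compound 1 to compound 2 touches this ring, and that step, a 1.4-fold higher number from compound 1 to compound 2 (0.15 log units; within the scatter), stayed within the scatter although it changed more than a single methyl. A second methyl is therefore expected to move the number in this assay little, in no clear direction. For compound 3 the expected step is a 1.1-fold higher number from compound 2 to compound 3 (0.05 log units; within the scatter). Compound 3 is estimated at 100 nM, with a range from 40 nM to 250 nM.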

Compound 3, half-maximal effective concentration: 90 nM
Estimate against measurement, compound 3: 1.1-fold (0.05 log units) above; the measured number falls inside the stated range.
By their numbers in this assay, from the lowest: compounds 1, 2 and 3 (each within the scatter of the next).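

Adding a second methyl group, which turns 3-methylphenyl into 3,5-dimethylphenyl, gives a 1.0-fold higher number from compound 2 to compound 3 (0.00 log units; within the scatter) in this assay; this is the first step here that isolates a single methyl, and a methyl on this aromatic carbon, meta to a large group and meta to a methyl group, produces no readable change. Compared with the 3-chloro-4-fluorophenyl ring of compound 1, the 3,5-dimethylphenyl ring gives a 1.4-fold higher number from compound 1 to compound 3 (0.15 log units; within the scatter), so the three rings on the carbonyl carbon, which carry different groups in different places, cannot be told apart in this assay and the series shows no ranking among them. No measurement is available that could explain why the number stays so flat across these rings.

On these data alone, whether a carboxylic acid or an amine on this ring, or a longer chain such as propyl in place of the methyl, would shift the number remains open. All three compounds also share the same core and amide link, so they cannot show how much the number depends on those parts of the molecule.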